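This account rests on a few compounds, and the source may have more. Where it says the series, first, only, none or still open, it means among the compounds named here.

Compound 2 `CC(=O)N1c2ccccc2CCC1C(=O)Nc1cc(C(F)(F)F)cc(C(F)(F)F)c1` is an amide carrying an acetyl group on its ring nitrogen. In a functional assay on NCI-H23 cells (Homo sapiens) for cytotoxicity, read by sulforhodamine B assay, with a stated time of 72 h (on this read-out higher numbers stand for weaker inhibition of growth and lower numbers for stronger inhibition of growth), compound 2 gives only a limit, > 70000 nM, so no exact number is known for it. It thus sits at the limit of > 70000 nM in this assay, at which 1 of the 3 values shown sits. Two related compounds were measured alongside it. Compound 1 `O=C(Nc1ccccc1C(F)(F)F)c1ccc2ccccc2n1` also gives only a limit in this assay, > 90000 nM. Compound 3 `O=C(Nc1ccccc1O)c1ccc2ccccc2n1` gives 87500 nM in this assay. Among the compounds with values here, the single measured step, an at least 1.0-fold lower number from compound 1 to compound 3 (0.01 log units; that floor lies within the scatter), exchanges a group on an aromatic carbon and lies within the scatter.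

Compound 4 `O=C(Nc1cc(C(F)(F)F)cc(C(F)(F)F)c1)C1CCc2ccccc2N1C(=O)c1ccccc1` differs from compound 2 in one place: phenyl in place of methyl on a carbonyl carbon. Within the data shown here, no measured step touches a carbonyl carbon or exchanges acetyl for benzoyl, so the data give no guide to the size or direction of this step. Since every number shown is weak or only a limit, compound 4 is expected to remain weak, with an estimated 70000 nM and a range from 20000 nM to 200000 nM. The expected step is therefore a number no higher from compound 2 to compound 4 (the limit leaves the size open), within the scatter, and most likely the assay would again report only a limit.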

Compound 4, concentration for 50% growth inhibition: 2130 nM
Estimate against measurement, compound 4: 33-fold (1.52 log units) above; measured number outside the range, below it.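

In this assay, the exchange of phenyl for methyl on a carbonyl carbon gives an at least 32-fold lower number from compound 2 to compound 4 (1.51 log units; beyond the scatter), so this position, unlike the aromatic carbon changed in the earlier step, can shift growth inhibition well beyond the scatter. This is a floor and not an exact size, and the true step may be larger, because compound 2 gives only a limit: the limit of > 70000 nM in this assay, at which 1 of the 4 values shown sits. A single change on this carbonyl carbon is thus enough to turn a compound that reaches no measurable value into one with a real number.

With only acetyl and benzoyl shown at this place, it stays open whether the gain needs an aromatic ring or only more carbon atoms. A cyclohexyl group, a longer chain such as butyl, or a pyridine ring on the same carbonyl carbon would help to separate these possibilities.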